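Replacing cyclopentyl with 4-methylphenyl on a quinone amine

The compounds below may be only part of what the source reports. "The series", "measured", "known", "first", "only" and "open" are said of these compounds alone.

Measured so far:
compound 1, `O=C1C(Nc2ccccc2F)=CC(=O)c2c1nc1n2[C@H]2OC[C@@H](O)[C@H]2OC1` — 9820 nM
compound 2, `Cc1ccc(NC2=CC(=O)c3c(nc4n3[C@H]3OC[C@@H](O)[C@H]3OC4)C2=O)cc1` — 6590 nM
compound 3, `O=C1C=C(NC2CCCC2)C(=O)c2c1nc1n2[C@H]2OC[C@@H](O)[C@H]2OC1` — > 16000 nM

Of the compounds shown here, three sharing a core have been tested in a functional assay on HeLa cells (Homo sapiens) for inhibition, read by sulforhodamine B assay; on this read-out lower numbers stand for stronger inhibition and higher numbers for weaker inhibition. Going by the values given here, compound 1 gives 9820 nM and compound 2 gives 6590 nM; the only measured step between them, a 1.5-fold lower number from compound 1 to compound 2 (0.17 log units; within the scatter), is small. Compound 3, which carries a cyclopentylamino group, gives only a limit in this assay: > 16000 nM, and the limit of > 16000 nM in this assay, at which 1 of the 3 values shown sits, shows that this limit is where compound 3 stands, so its true value is not known beyond that.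

Compound 4, `Cc1ccc(NC2=CC(=O)c3nc4n(c3C2=O)[C@H]2OC[C@@H](O)[C@H]2OC4)cc1`, is yet to be measured. It differs from compound 3 in one place: 4-methylphenyl in place of cyclopentyl on an amine nitrogen. Among the compounds with values here, the single measured step concerns one aryl group replacing another and does not cover an aryl group replacing a saturated ring, so it bears on this change only weakly. Since compound 1 and compound 2, both carrying aryl amines, give numbers rather than limits, compound 4 is expected to give a number as well, with an at least 2.0-fold lower number from compound 3 to compound 4 (0.30 log units; that floor lies within the scatter) as the expected step. For compound 4 the estimate is 8000 nM, ranging from 3000 nM to 20000 nM.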

Compound 4, half-maximal inhibitory concentration: 3860 nM
The estimate for compound 4 lay 2.1-fold (0.32 log units) above the measured number; measured number inside the range.
By their numbers in this assay, from the lowest: compounds 4, 2 and 1 (each within the scatter of the next, the first and the last beyond it). At a limit, above all of these: compound 3.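

Putting 4-methylphenyl in place of cyclopentyl on the amine nitrogen moves the read-out in this assay by an at least 4.1-fold lower number from compound 3 to compound 4 (0.61 log units; beyond the scatter). Going by these compounds alone, the earlier compounds compared only one aryl group with another, so this is the first sign that the kind of ring on this nitrogen matters, at least for this pair. The true size of the step remains unknown, and the printed size is only a floor, because compound 3 stands at a limit of the assay: the limit of > 16000 nM in this assay, at which 1 of the 4 values shown sits.

The compounds shown leave open whether the aromatic ring itself or its methyl group accounts for the change. They also leave open how an unsubstituted phenyl, an open butyl chain or a phenyl ring bearing a carboxylic acid would behave on this nitrogen.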